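Swapping 3-chlorophenyl for (2-chlorophenyl)carbonyl in compound 1

The compounds below may be only part of what the source reports. "The series", "measured", "known", "first", "only" and "open" are said of these compounds alone.

Within the data shown here, in a functional assay on OVCAR-3 cells (Homo sapiens) for antiproliferative activity, read by MTT assay, with a stated time of 24 h (a lower number here means a stronger inhibitor, a higher number a weaker inhibitor), compound 1 `O=C(NNc1cccc(Cl)c1)c1ccccc1NS(=O)(=O)c1cnc(O)nc1O` gives 5520 nM as the only true number so far. Compound 2 `Cc1ccccc1C(=O)NNC(=O)c1ccc(NS(=O)(=O)c2cnc(O)nc2O)cc1` reports > 20000 nM which is a limit of the assay and not a number. Compound 3 `O=C(NNC(=O)c1ccccc1NS(=O)(=O)c1cnc(O)nc1O)c1ccccc1Cl` differs from compound 1 by (2-chlorophenyl)carbonyl in place of 3-chlorophenyl on an amine nitrogen with (2-chlorophenyl)carbonyl in place of 3-chlorophenyl on an amine nitrogen. Among the measured compounds shown here, no measured step shows what such a swap does. A modest weakening in this assay is expected, an estimated 2.0-fold higher number from compound 1 to compound 3 (0.30 log units; within the scatter) overall. Compound 3 is expected at 11000 nM and estimated to fall between 4000 nM and 25000 nM as a rough expectation.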

Compound 3, half-maximal inhibitory concentration: 18200 nM
Compound 3: the middle estimate sits 1.7-fold (0.22 log units) below what was measured; the measured number falls inside the stated range.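

In this assay, among these compounds, (2-chlorophenyl)carbonyl in place of 3-chlorophenyl on an amine nitrogen gives a 3.3-fold higher number from compound 1 to compound 3 (0.52 log units; beyond the scatter), the first measured step at this place. The place is therefore not indifferent to what it carries, and this change weakens the compound. Compound 2 reports a limit of the assay and not a number: the limit of > 20000 nM in this assay, at which 1 of the 3 values shown sits.

The swap adds a carbonyl and changes the chlorine position at once, and the compounds shown do not separate the two. A (3-chlorophenyl)carbonyl group at this nitrogen would tell them apart.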